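Amino in place of methoxy: compound 3 to compound 4

The source may report more compounds than this note shows. Statements on the series, on what has been measured and on what is new or still open speak of the compounds shown alone.

In an in vitro ADME assay on microsomes from liver (Rattus norvegicus) for metabolic stability (a higher number here means faster removal of the compound, a lower number slower removal), compound 3 `COc1ccc(Cn2c(=O)[nH]c3c(N)nc(C(F)(F)F)cc32)cn1` gives < 9 mL.min-1.g-1 as its reading, and this is a limit of the assay, not a number. Compound 1 `Cc1nc(Cn2c(=O)[nH]c3c(N)nc(C(F)(F)F)cc32)co1` is also reported only as a limit, at < 10 mL.min-1.g-1 in this assay. Within the data shown here, compound 2 `CN1CCN(c2ccc(Cn3c(=O)[nH]c4c(N)nc(C(F)(F)F)cc43)cn2)CC1` is the one compound of the three with a number, at 46 mL.min-1.g-1 in this assay.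

Compound 4 `Nc1ccc(Cn2c(=O)[nH]c3c(N)nc(C(F)(F)F)cc32)cn1` has amino in place of methoxy on an aromatic carbon, next to the ring nitrogen and para to a large group: amino in place of methoxy on an aromatic carbon. The same difference reads as 6-methoxypyridin-3-yl to 6-aminopyridin-3-yl.

The closest measured change is an at least 5.1-fold lower number from compound 2 to compound 3 (0.70 log units; beyond the scatter) with methoxy in place of 4-methylpiperazin-1-yl on an aromatic carbon. Also available is a step that the two limits leave unreadable from compound 1 to compound 3 with 6-methoxypyridin-3-yl in place of 2-methyl-1,3-oxazol-4-yl, and this one gives no size to work from. Amino brings no ring, unlike the 4-methylpiperazin-1-yl group of compound 2 at 46 mL.min-1.g-1 and so a jump of that size is not expected here. The expected step is a step that the limit leaves unreadable from compound 3 to compound 4 and it is not expected to lie beyond the scatter in this assay. Compound 4 is estimated at 8 mL.min-1.g-1 with an expected range of 4 mL.min-1.g-1 to 18 mL.min-1.g-1.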

Compound 4, intrinsic clearance in microsomes: < 10 mL.min-1.g-1
Compound 4 ended at the assay's limit; the forecaster's own chance of this, stated with the estimate: 55%; the middle value does not contradict the limit.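

In this assay compound 4 gives < 10 mL.min-1.g-1, which is a limit of the assay and not a number. Amino in place of 4-methylpiperazin-1-yl on this aromatic carbon, next to the ring nitrogen and para to a large group, gives an at least 4.6-fold lower number from compound 2 to compound 4 (0.66 log units; beyond the scatter), so the lower reading seen with methoxy, an at least 5.1-fold lower number from compound 2 to compound 3 (0.70 log units; beyond the scatter), now holds for a second small group, one that carries a hydrogen-bond donor where methoxy carries none. The steps between compound 3 and compound 4 and between compound 1 and compound 4 cannot be read, because the values at both ends of each are limits: the limit of < 10 mL.min-1.g-1 in this assay, at which 2 of the 4 values shown sit.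

Going by these compounds, how far methoxy and amino stand apart in this assay stays open, since neither compound has a number that could set the size of that change. On these data alone, it also stays open whether the high reading of compound 2 goes with the ring of 4-methylpiperazin-1-yl or with its amine nitrogens, and a morpholine or a dimethylamino group on the same aromatic carbon would separate those two readings.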